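The source may hold more compounds than are shown below. What is called first, only, known or untested is meant among the compounds shown, and "the series" means these compounds.

In a functional assay on HL-60 cells (Homo sapiens) for inhibition, read by CCK-8 assay, with a stated time of 48 h (on this read-out lower numbers stand for stronger inhibition and higher numbers for weaker inhibition), two compounds have been measured so far:
compound 1 `Cc1cc(C)cc(NC(=O)NCCNS(=O)(=O)c2ccc(-c3ccccc3Oc3ccc([N+](=O)[O-])c([N+](=O)[O-])c3)s2)c1` gives 9100 nM
compound 2 `COc1cccc(NC(=O)NCCNS(=O)(=O)c2ccc(-c3ccccc3OCc3ccccc3)s2)c1` gives 1700 nM

Compound 2 holds the lower of the two numbers, and its gap to compound 1 lies beyond the scatter. Compound 3 `COc1cccc(NC(=O)NCCNS(=O)(=O)c2ccc(-c3ccccc3Oc3ccc([N+](=O)[O-])c([N+](=O)[O-])c3)s2)c1` keeps the rest of compound 2 but carries 3,4-dinitrophenyl in place of benzyl on an oxygen on an aromatic ring. Compound 1 at 9100 nM carries the same 3,4-dinitrophenyl but differs from compound 3 elsewhere, so a moderate step toward weaker inhibition in this assay is expected, beyond the scatter. An estimated 2.4-fold higher number from compound 2 to compound 3 (0.37 log units; beyond the scatter) is what this implies. For compound 3 the expected value is 4000 nM (estimated range 1300 nM to 12000 nM).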

Compound 3, half-maximal inhibitory concentration: 6700 nM
Beside the measured number, compound 3's estimate is 1.7-fold (0.22 log units) below it; the range from low to high includes it.
By their numbers in this assay, from the lowest: compound 2; then compounds 3 and 1 (each within the scatter of the next).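

In this assay, 3,4-dinitrophenyl in place of benzyl on an oxygen on an aromatic ring gives a step beyond the scatter (a 3.9-fold higher number from compound 2 to compound 3 (0.60 log units; beyond the scatter)), so this position responds to the change of group. With 3,4-dinitrophenyl held, 3-methoxyphenyl in place of 3,5-dimethylphenyl on an amide-type nitrogen gives a step within the scatter (a 1.4-fold lower number from compound 1 to compound 3 (0.13 log units; within the scatter)), so these two groups cannot be told apart here. Nothing at hand explains the step at the oxygen.

As far as these compounds go, it remains open whether that step follows the two nitro groups or the loss of the benzyl carbon. A plain phenyl on the same oxygen would separate the two.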